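Compound 2 to compound 3: a fluoro step

This account rests on a few compounds, and the source may have more. Where it says the series, first, only, none or still open, it means among the compounds named here.

Among the compounds with values here, in a functional assay on MCF7 cells (Homo sapiens) for antiproliferative activity, read by sulforhodamine B assay, with a stated time of 48 h (on this read-out lower numbers stand for stronger inhibition and higher numbers for weaker inhibition), compound 2 (`CO/N=C1/C(=O)N(CCCCCCC(=O)NO)c2ccccc21`) gives 1710 nM and holds the higher of the two numbers so far. In this assay compound 1 (`O=C(CCCCCCN1C(=O)/C(=N\O)c2cc(Cl)ccc21)NO`) gives 680 nM and the gap between them lies beyond the scatter. Within the data shown here, these two compounds differ in more than one place, so the gap cannot be assigned to any single change, and no measured step in one place exists as a guide.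

Compound 3 (`CO/N=C1/C(=O)N(CCCCCCC(=O)NO)c2ccc(F)cc21`) has fluoro in place of hydrogen on an aromatic carbon of compound 2 (fluoro in place of hydrogen on an aromatic carbon). Among the measured compounds shown here, with no such step to draw on, the expectation stays anchored on compound 2 at 1710 nM and no change beyond the scatter is expected in this assay, with at most a slight lean toward a lower number. The expected 1.3-fold lower number from compound 2 to compound 3 (0.12 log units; within the scatter) should therefore remain small. For compound 3 the estimated value is 1300 nM (expected range 550 nM to 3000 nM).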

Compound 3, half-maximal inhibitory concentration: 2420 nM
Estimate against measurement, compound 3: 1.9-fold (0.27 log units) below, within the range that was stated.
By their numbers in this assay, from the lowest: compound 1; then compounds 2 and 3 (each within the scatter of the next).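

In this assay, within the data shown here, fluoro in place of hydrogen on this aromatic carbon gives a 1.4-fold higher number from compound 2 to compound 3 (0.15 log units; within the scatter), the first step that can be read in one place. On this shared core and with this chain, the position therefore accepts fluoro with no change beyond the scatter, which the earlier pair, differing in more than one place, could not show. Nothing available explains the size of this step.

Only this one substituent at this one carbon can be read, so the step says nothing yet about larger or differently built groups there. As far as these compounds go, whether a trifluoromethyl, a nitrile or an amine at this carbon, or a longer chain on compound 2, would move the number beyond the scatter remains open.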